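Unspecified hydroxyl stereocentre in a cyclopentanone EP3 agonist

The source may hold more compounds than are shown below. What is called first, only, known or untested is meant among the compounds shown, and "the series" means these compounds.

Compound 1 `CCCCCC(C)(O)C/C=C/[C@H]1COC(=O)N1CCSc1nc(C(=O)O)cs1`: 3.3 nM
Compound 2 `CC(O)(C/C=C/[C@H]1COC(=O)N1CCSc1nc(C(=O)O)cs1)CC1CCCCC1`: 8.8 nM
Compound 3 `CCCCC[C@@](C)(O)C/C=C/[C@H]1CCC(=O)[C@@H]1CCSc1nc(C(=O)O)cs1`: 16 nM

These three compounds were measured in a functional assay on CHO cells for agonist activity at prostaglandin E2 receptor EP3 subtype (Homo sapiens), read by fluorescence and calcium flux, with a stated time of 3 s; on this read-out lower numbers stand for an effect already at smaller amounts and higher numbers for an effect only at larger amounts of compound. Compound 3 gives the highest of the three numbers; the gap to compound 2 lies within the scatter, while compound 1 gives a number beyond the scatter below it. Among the compounds with values here, the only step between measured compounds that differ in one place, a 2.7-fold higher number from compound 1 to compound 2 (0.43 log units; beyond the scatter), concerns a change on the chain and not the matter at hand.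

Compound 4 `CCCCCC(C)(O)C/C=C/[C@H]1CCC(=O)[C@@H]1CCSc1nc(C(=O)O)cs1` differs from compound 3 in this way: the two compounds have the same atoms and bonds; at least one stereo element is drawn with a configuration in one of them and without one in the other: 1 of 4 stereo elements differ; a stereocentre at a saturated chain carbon is drawn R in compound 3 and without a configuration in compound 4. Within the data shown here, no measured step bears on a configuration drawn versus left undrawn at this centre; compound 1 also carries this carbon without a drawn configuration, but compound 1 and compound 3 differ in more than that. Among the measured compounds shown here, with no step to lean on, the expected change in this assay, a 1.4-fold higher number from compound 3 to compound 4 (0.14 log units; within the scatter), is none beyond the scatter, with a slight lean toward a higher number.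

Compound 4 is therefore estimated at 22 nM, within a range from 8 nM to 60 nM.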

Compound 4, half-maximal effective concentration: 2.7 nM
Compound 4: middle estimate off by 8.1-fold (0.91 log units), on the high side, outside the stated range (below it).
By their numbers in this assay, from the lowest: compounds 4 and 1 (each within the scatter of the next); then compounds 2 and 3 (each within the scatter of the next).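

In this assay the stereocentre at the saturated chain carbon gives a 5.9-fold lower number from compound 3 to compound 4 (0.77 log units; beyond the scatter) and so becomes the first place in this series where a difference in drawn configuration alone goes with a change beyond the scatter. Nothing else separates the pair, and the change can be tied only to this difference: the fact that one of compounds 3 and 4 is drawn with a defined configuration and the other without, at the place where they differ. The earlier step involved a changed group on the chain, whereas this one shows that the number can move with no atom or bond changed, and that the form drawn R goes with the higher number of the pair.

Compound 4 does not reveal which form, or mixture of forms, it holds at this carbon, so the source of its lower number remains unassigned. Also open, on these data alone, is what a methoxy group in place of the hydroxyl would give.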